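The source may report more compounds than this note shows. Statements on the series, on what has been measured and on what is new or still open speak of the compounds shown alone.

Among the two compounds measured, compound 2 `NNC(=O)Cc1cc(=O)oc2cc(OCc3cccc(Cl)c3)ccc12` carries the lowest number in an assay for inhibition of Amine oxidase [flavin-containing] B (Rattus norvegicus) (on this read-out lower numbers stand for stronger inhibition and higher numbers for weaker inhibition), where compound 2 gives 90 nM. Among the measured compounds shown here, its only measured neighbour is compound 1 `NC(=O)[C@H](CO)Nc1cc(=O)oc2cc(OCc3cccc(Cl)c3)ccc12`; in this assay compound 1 gives 2400 nM, and the single measured step, a 27-fold lower number from compound 1 to compound 2 (1.43 log units; beyond the scatter), joins them. Compound 3 `O=C(Cc1cc(=O)oc2cc(OCc3cccc(Cl)c3)ccc12)NCc1ccccc1` has not yet been measured. It differs from compound 2 by benzyl in place of amino on an amide-type nitrogen. For the measured compounds named here, no measured step touches the amide-type nitrogen: the one step recorded exchanges the whole side chain at the aromatic carbon, so it shows only that this region tolerates large changes in the number, not what a benzyl on the amide nitrogen would do. Lacking a direct precedent, the expectation for compound 3 is a modest step, a 1.7-fold higher number from compound 2 to compound 3 (0.22 log units; within the scatter), with wide uncertainty. Compound 3 is therefore estimated at 150 nM, expected between 20 nM and 1500 nM.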

Compound 3, half-maximal inhibitory concentration: 5000 nM
Compound 3: the middle estimate sits 33-fold (1.52 log units) below what was measured; the measured number lies above the stated range.
By their numbers in this assay, from the lowest: compound 2; then compound 1; then compound 3.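

In this assay the exchange on the amide-type nitrogen gives a 56-fold higher number from compound 2 to compound 3 (1.74 log units; beyond the scatter) and so counts as a large step, as did a 27-fold lower number from compound 1 to compound 2 (1.43 log units; beyond the scatter) for the exchange of the whole side chain at the aromatic carbon. The earlier compounds shown here tied a large change in the number only to that whole side chain, whereas this step ties one to a single substituent on the amide-type nitrogen, with the rest of the structure unchanged. Nothing available explains the size of this step.
On these data alone, with only amino and benzyl on this nitrogen, it remains open whether a small methyl group or a hydroxyl group would keep the number near that of compound 2 or move it toward that of compound 3. As far as these compounds go, it is equally open whether a phenyl group or a longer phenylethyl chain would behave as benzyl does.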